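The compounds below may be only part of what the source reports. "The series", "measured", "known", "first", "only" and "open" are said of these compounds alone.

Measured in an ADME assay on L02 cells (Homo sapiens) for antiproliferative activity, read by MTT assay, with a stated time of 48 h; a lower number here means a stronger inhibitor, a higher number a weaker inhibitor:
- Compound 1 `C=CCN(C)C(=O)c1ccc(C(CC)(CC)c2ccc(OCCC(O)(CC)CC)c(C)c2)n1CC`: 1190 nM
- Compound 2 `CCOc1ccc(NC(=O)c2ccc(C(CC)(CC)c3ccc(OCCC(O)(CC)CC)c(C)c3)n2CC)cc1`: > 50000 nM (a limit, not a number)

Compound 2 sits at the limit of > 50000 nM in this assay, at which 1 of the 2 values shown sits. Compound 3 `CCOC(=O)C(CC(=O)OC)NC(=O)c1ccc(C(CC)(CC)c2ccc(OCCC(O)(CC)CC)c(C)c2)n1CC` differs from it by a group of 11 heavy atoms (7 carbon, 4 oxygen; no ring) in place of a group of 9 heavy atoms (8 carbon, 1 oxygen; one six-membered aromatic ring of carbon only), on an amide-type nitrogen. For the measured compounds named here, the one measured step that bears on this change, an at least 42-fold higher number from compound 1 to compound 2 (1.62 log units; beyond the scatter), is large and beyond the scatter, and it brought in the 4-ethoxyphenyl that now leaves. A move back towards a lower number is therefore expected, though with a single step to go on, its size is uncertain. The expected change is an at least 3.3-fold lower number from compound 2 to compound 3 (0.52 log units; beyond the scatter). The estimate for compound 3 is 15000 nM, with an expected range of 3000 nM to 50000 nM.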

Compound 3, half-maximal inhibitory concentration: 4280 nM
Compound 3: middle estimate off by 3.5-fold (0.54 log units), on the high side, within the range that was stated.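

On the amide-type nitrogen, an open-chain group in place of 4-ethoxyphenyl brings the series back to a measurable number in this assay: an at least 11-fold lower number from compound 2 to compound 3 (1.06 log units; beyond the scatter). As far as these compounds go, compound 2 is held only as a limit, so the true size of that step stays unknown: the limit of > 50000 nM in this assay, at which 1 of the 3 values shown sits. The recovery is partial, with a 3.6-fold higher number from compound 1 to compound 3 (0.56 log units; beyond the scatter), leaving the allyl(methyl)amino group of compound 1 with the lowest number of the three.

Open, from the compounds shown here alone, is whether the lower number of compound 3 goes with the loss of the 4-ethoxyphenyl ring or with the group that enters. A plain butyl chain or a carboxylic acid on the same nitrogen would bear on that.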